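The compounds below may be only part of what the source reports. "The series", "measured", "known", "first", "only" and "open" are said of these compounds alone.

Working notes on the series. For compound 1 (`CCOC(=O)c1cc(/C=C/c2ccccc2C(F)(F)F)on1`) the entry in an ADME assay on Vero cells (Chlorocebus sabaeus) for cytotoxicity, with a stated time of 72 h (a higher number here means a weaker inhibitor, a lower number a stronger inhibitor), reads "not determined" (no result reported) and gives no number to work from. Compound 2 (`CCOC(=O)c1cc(/C=C/c2cccc(C)c2)on1`) stands at > 128000 nM in this assay, which is a limit of the assay and not a number. Among the measured compounds shown here, this is the only reading so far (the limit of > 128000 nM in this assay, at which 1 of the 2 values shown sits). Compound 3 (`CCOC(=O)c1cc(/C=C/c2cccc(-c3ccccn3)c2)on1`) is still unmeasured. It carries pyridin-2-yl in place of methyl on an aromatic carbon, meta to a large group (pyridin-2-yl in place of methyl on an aromatic carbon). For the measured compounds named here, no measured step gives a scale for this change. A moderate shift towards stronger inhibition in this assay is expected, with the estimated step being an at least 1.6-fold lower number from compound 2 to compound 3 (0.20 log units; that floor lies within the scatter) and its size uncertain. Compound 3 is estimated at 80000 nM (expected range 25000 nM to 128000 nM), and a further limit reading would not be a surprise.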

Compound 3, half-maximal inhibitory concentration: 113000 nM
Compound 3: the middle estimate sits 1.4-fold (0.15 log units) below what was measured, and the stated range covers the measured number.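

With pyridin-2-yl in place of methyl on an aromatic carbon, meta to a large group, the series gains its first readable step in this assay: an at least 1.1-fold lower number from compound 2 to compound 3 (0.05 log units; that floor lies within the scatter). Among the compounds shown here, compound 3 also gives the first single number, 113000 nM, so this place can carry an added aromatic ring with one hydrogen-bond acceptor and still return a value in this assay. As far as these compounds go, the limit belongs to compound 2, so the step is only a floor and its true size stays unknown: the limit of > 128000 nM in this assay, at which 1 of the 3 values shown sits.

The compounds shown leave open how a plain phenyl ring or an amine at this aromatic carbon would read, and so whether the ring nitrogen of pyridin-2-yl plays any part. They also leave open what a carboxylic acid on the shared core would do in this assay.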